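The source may report more compounds than this note shows. Statements on the series, on what has been measured and on what is new or still open speak of the compounds shown alone.

In a functional assay on HL-60 cells (Homo sapiens) for inhibition, read by CCK-8 assay, with a stated time of 48 h (a higher number here means a weaker inhibitor, a lower number a stronger inhibitor), two compounds have been measured so far. Compound 1 (`O=C(NCCNS(=O)(=O)c1ccc(-c2ccccc2O[C@H]2CC[C@H](O)CC2)s1)Nc1ccc([N+](=O)[O-])cc1`) gives 8900 nM. Compound 2 (`O=C(NCCNS(=O)(=O)c1ccc(-c2ccccc2Oc2ccc([N+](=O)[O-])c([N+](=O)[O-])c2)s1)Nc1cc(Cl)cc(Cl)c1`) gives 2300 nM, the lower of the two numbers, and its gap to compound 1 lies beyond the scatter. Among the measured compounds shown here, these two compounds differ in more than one place, so no step at a single position has been measured. Compound 3 (`O=C(NCCNS(=O)(=O)c1ccc(-c2ccccc2O[C@H]2CC[C@H](O)CC2)s1)Nc1cc(Cl)cc(Cl)c1`) follows from compound 2 by one change: 4-hydroxycyclohexyl in place of 3,4-dinitrophenyl on an oxygen on an aromatic ring. Compound 1 also carries 4-hydroxycyclohexyl on that oxygen. A moderate weakening in this assay is therefore expected, with the number rising towards that of compound 1 at 8900 nM, although the data hold no direct measure of this change. The expected change is a 2.0-fold higher number from compound 2 to compound 3 (0.29 log units; within the scatter). For compound 3 the estimated value is 4500 nM, with an expected range from 1500 nM to 12000 nM.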

Compound 3, half-maximal inhibitory concentration: > 20000 nM
Compound 3 ended at the assay's limit; the forecaster's own chance of this, stated with the estimate: 5%; at least 4.4-fold (0.64 log units) between middle value and limit.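

In this assay, among the compounds shown here, the step at this oxygen is an at least 8.6-fold higher number from compound 2 to compound 3 (0.93 log units; beyond the scatter), the first reading of this position, and it shows that 4-hydroxycyclohexyl in place of 3,4-dinitrophenyl costs clear activity. With 4-hydroxycyclohexyl held on that oxygen, 3,5-dichlorophenyl in place of 4-nitrophenyl on the amide-type nitrogen gives an at least 2.2-fold higher number from compound 1 to compound 3 (0.35 log units; beyond the scatter), so this group does not restore activity in that setting. The value of compound 3 is a limit of the assay and not a number, so both steps give only a minimum size: the limit of > 20000 nM in this assay, at which 1 of the 3 values shown sits.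

As far as these compounds go, the true size of each step stays open, as does how 3,4-dinitrophenyl would behave with 4-nitrophenyl on the amide-type nitrogen. Also open, from the compounds shown here alone, is whether the gain at the oxygen needs both nitro groups, or whether an unsubstituted phenyl or a 4-aminophenyl there would keep it.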